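The compounds below may be only part of what the source reports. "The series", "measured", "known", "first", "only" and "open" are said of these compounds alone.

Measured so far:
compound 1 `Cc1ccc(NC(=O)CC(=O)O)c2ccn(Cc3ccc(O)c(C(C)C)c3)c12` gives 5200 nM
compound 2 `Cc1cc2c(NC(=O)CC(=O)O)cccc2n1Cc1ccc(O)c(C(C)C)c1` gives 5200 nM
compound 3 `Cc1c(CCC(=O)O)c2ccccc2n1Cc1ccc(O)c(C(C)C)c1` gives 1300 nM

All three were examined in an assay on isolated protein for displacement of a labelled ligand from thyroid hormone receptor alpha (Homo sapiens), with a stated time of 3 h; a higher number here means a weaker inhibitor, a lower number a stronger inhibitor. Compound 1 and compound 2 return the same number there, so nothing separates them. Compound 3 holds the lowest of the three values, and its distance to both compound 1 and compound 2 lies beyond the usual scatter, which makes it the strongest inhibitor of the measured set.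

The next compound, compound 4 `Cc1c(CCCCC(=O)O)c2ccccc2n1Cc1ccc(O)c(C(C)C)c1`, has not been measured. It differs from compound 3 in one place: 2-carboxyethyl in place of carboxy on a saturated chain carbon, two bonds along the chain from an aromatic carbon. The acid end of the chain is thus carried further away from the aromatic carbon while the donor and acceptor count stays the same.

Going by the values given here, no directly comparable pair among the measured compounds shows what such a chain extension does in this assay. Compound 1, whose acid also sits further out along an attachment, gives 5200 nM, and compound 2, with the same arrangement, gives 5200 nM; both are weaker than compound 3. On that basis a step toward a weaker inhibitor is expected, moderate in size, with a fair chance it stays within the scatter. The step from compound 3 to compound 4 is estimated as a 2.3-fold higher number from compound 3 to compound 4 (0.36 log units; beyond the scatter). Compound 4 is expected to give 3000 nM, in the range 800 nM to 12000 nM.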

Compound 4, half-maximal inhibitory concentration: > 10000 nM
Compound 4 gave a limit, no number; the forecaster's own chance of this, stated with the estimate: 10%; middle value at least 3.3-fold (0.52 log units) away from the limit.
By their numbers in this assay, from the lowest: compound 3; then compounds 1 and 2 (each within the scatter of the next). At a limit, above all of these: compound 4.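

In this assay, going by these compounds alone, the change from carboxy to 2-carboxyethyl on a saturated chain carbon, two bonds along the chain from an aromatic carbon, gives an at least 7.6-fold higher number from compound 3 to compound 4 (0.88 log units; beyond the scatter), and this is the first directly comparable pair in the set. It shows that the length of the acid-bearing chain at this position matters in its own right: lengthening the chain in this one place, with the other parts of compound 3 left as they are and the hydrogen-bond donor and acceptor counts unchanged, moves the result beyond the scatter toward a weaker inhibitor. The value of compound 4 is a limit and not a number, so this step fixes a direction and a minimum size only: the limit of > 10000 nM in this assay, at which 1 of the 4 values shown sits.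

The compounds shown leave open how the response changes across intermediate or shorter lengths, since carboxymethyl and 3-carboxypropyl chains on the same aromatic carbon are absent from this set. They also leave open whether an amide or an alcohol at the chain end would behave as the carboxylic acid does in compound 3.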